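Chain-lengthened isothiocyanates on a shared core

The compounds below may be only part of what the source reports. "The series", "measured", "known", "first", "only" and "open" are said of these compounds alone.

Measured so far in a functional assay on NCI-H1299 cells (Homo sapiens) for inhibition, read by CCK-8 assay, with a stated time of 72 h, tested at 1 uM; a lower number here means a weaker effect, a higher number a stronger effect of the compound at the concentration tested:
Compound 1 `CN(C)C(=O)c1cc2cnc(Nc3ccc(S(=O)(=O)NCCCN=C=S)cc3)nc2n1C1CCCC1` gives 41.3%.
Compound 2 `CN(C)C(=O)c1cc2cnc(Nc3ccc(S(=O)(=O)NCCCCN=C=S)cc3)nc2n1C1CCCC1` gives 29.9%.
Compound 3 `CN(C)C(=O)c1cc2cnc(Nc3ccc(C(=O)NCCCCN=C=S)cc3O)nc2n1C1CCCC1` gives 10.7%.

Going by the values given here, the one stepwise change measured is a group of 4 heavy atoms (2 carbon, 1 nitrogen, 1 sulfur; no ring) in place of a group of 3 heavy atoms (1 carbon, 1 nitrogen, 1 sulfur; no ring), on a saturated chain carbon, three bonds along the chain from a sulfonamide nitrogen, and that step is a number 11.4 percentage points lower from compound 1 to compound 2 (beyond the scatter). Compound 3 carries a different core from compound 1; the difference between the two cores is not broken down here, and compound 3 stands lowest of the three in this assay, beyond the scatter from both compound 2 and compound 1.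

Compound 4 `CN(C)C(=O)c1cc2cnc(Nc3ccc(C(=O)NCCCCCN=C=S)cc3O)nc2n1C1CCCC1` is not yet measured. It relates to compound 3 by a group of 4 heavy atoms (2 carbon, 1 nitrogen, 1 sulfur; no ring) in place of a group of 3 heavy atoms (1 carbon, 1 nitrogen, 1 sulfur; no ring), on a saturated chain carbon, four bonds along the chain from an amide-type nitrogen. This is the same kind of change as that from compound 1 to compound 2, but not the same: there the place was three bonds along the chain from a sulfonamide nitrogen, here it is four bonds along the chain from an amide-type nitrogen.

For compound 4 the expected step is a number 4.7 percentage points lower from compound 3 to compound 4 (within the scatter), placed beside the measured a number 11.4 percentage points lower from compound 1 to compound 2 (beyond the scatter), and smaller because compound 3 already sits at 10.7%, leaving little room to fall. Compound 4 is therefore estimated at 6%, expected within -8% to 22%.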

Compound 4, a percentage reported as inhibition, at one concentration (the size of the read-out at that concentration, not a potency): 22.6%
Compound 4: middle estimate off by 16.6 percentage points, on the low side; measured number outside the range, above it.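

In this assay, lengthening the isothiocyanate chain on the core of compound 3 gives a number 11.9 percentage points higher from compound 3 to compound 4 (beyond the scatter). The change therefore cannot be carried from one core to the other as a fixed increment, and even its direction does not hold across the two pairs: the same change on two cores in this assay, a number 11.4 percentage points lower (beyond the scatter) from compound 1 to compound 2 and a number 11.9 percentage points higher (beyond the scatter) from compound 3 to compound 4, 23.3 percentage points apart, beyond the scatter of two such steps

Going by these compounds alone, this does not show what reverses the step, since the two pairs differ both in the core and in the place of the change, three bonds along the chain from a sulfonamide nitrogen in one and four bonds along the chain from an amide-type nitrogen in the other, and only one pair stands on each core. The compounds shown leave open whether a still longer chain would continue either trend on its own core. They also leave open how either core would respond if an amine or a thiourea replaced the isothiocyanate group at the chain end.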